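Trading isopropyl for ethoxycarbonyl on compound 3

A few compounds are considered here, and "the series" means these few. Any claim that something is new, unique, unknown or untested is made for them only; others in the source may bear on it.

In a functional assay on MT4 cells (Homo sapiens) for cytotoxicity, read by MTT assay (on this read-out lower numbers stand for higher toxicity in this test and higher numbers for lower toxicity in this test), compound 3 `Cc1cc(C)cc(S(=O)(=O)c2c(C(=O)NNC(C)C)[nH]c3ccc(Cl)cc23)c1` gives > 100 uM, which is a limit and not a number. Compound 2 `O=C(NN1CCOC1=O)c1[nH]c2ccc(Cl)cc2c1S(=O)(=O)c1ccccc1` gives > 100 uM, which is also a limit. Compound 3 therefore stands at the limit of > 100 uM in this assay, at which 2 of the 3 values shown sit. Compound 1 `Cc1cc(C)cc(S(=O)(=O)c2c(C(=O)NCC(N)=O)[nH]c3ccc(Cl)cc23)c1` gives a true number, 45 uM.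

Compound 4 `CCOC(=O)NNC(=O)c1[nH]c2ccc(Cl)cc2c1S(=O)(=O)c1cc(C)cc(C)c1` has ethoxycarbonyl in place of isopropyl on an amine nitrogen. Among the compounds with values here, only one measured step bears on this change. It is an at least 2.2-fold higher number from compound 1 to compound 3 (0.34 log units; beyond the scatter), with isopropylamino in place of carbamoylmethyl on an amide-type nitrogen. That step shows that a swap in this part of the molecule can move the number beyond the scatter. Its size is known only as a minimum, so the guide is rough. A modest move toward a lower number, meaning higher toxicity, is expected, although a result at the limit remains quite possible. The expected step is an at least 1.4-fold lower number from compound 3 to compound 4 (0.15 log units; that floor lies within the scatter). For compound 4 the estimated value is 70 uM, with an expected range of 25 uM to 150 uM.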

Compound 4, half-maximal toxic concentration: 100 uM
For compound 4 the middle estimate is 1.4-fold (0.15 log units) below the measured one; the range from low to high includes it.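

In this assay, (ethoxycarbonyl)amino in place of carbamoylmethyl on an amide-type nitrogen gives a 2.2-fold higher number from compound 1 to compound 4 (0.35 log units; beyond the scatter), so a change in this part of the molecule now has a measured size and not only a minimum. Compound 3 sits at a limit of the assay: the limit of > 100 uM in this assay, at which 2 of the 4 values shown sit. The result is a number no higher from compound 3 to compound 4 (the limit leaves the size open), so this step cannot be read in size, but ethoxycarbonyl enters with hydrogen-bond acceptors that isopropyl lacks, and compound 4 still keeps clear of the lower number of compound 1.

Going by these compounds, how far compound 4 truly lies from compound 3 stays open. Also open, on these data alone, is whether a longer chain such as butoxycarbonyl, or a carboxylic acid in place of ethoxycarbonyl, on this amine nitrogen would move the number further.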